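A few compounds are considered here, and "the series" means these few. Any claim that something is new, unique, unknown or untested is made for them only; others in the source may bear on it.

Of the compounds shown here, three have been measured in an assay on isolated protein for displacement of a labelled ligand from melanin-concentrating hormone receptor 1 (Homo sapiens); a higher number here means a weaker inhibitor, a lower number a stronger inhibitor. Compound 1 `O=C(CCc1ccc(C(F)(F)F)cc1)Nc1ccc2nc(N3CCCCC3)ccc2c1` gives 12 nM, compound 2 `CCN(CC)c1ccc2cc(NC(=O)CCc3ccc(C(F)(F)F)cc3)ccc2n1` gives 88 nM, and compound 3 `CC(C)C(=O)NC1CCN(c2ccc3cc(NC(=O)CCc4ccc(C(F)(F)F)cc4)ccc3n2)C1` gives 1 nM. Compound 3 has the lowest number of the three: the change a 12-fold lower number from compound 1 to compound 3 (1.08 log units; beyond the scatter), and the change an 88-fold lower number from compound 2 to compound 3 (1.94 log units; beyond the scatter). Among the two simpler amines, a 7.3-fold higher number from compound 1 to compound 2 (0.87 log units; beyond the scatter).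

Compound 4 `CC1CCCN1c1ccc2cc(NC(=O)CCc3ccc(C(F)(F)F)cc3)ccc2n1` differs from compound 3 in one place: 2-methylpyrrolidin-1-yl in place of 3-((isopropylcarbonyl)amino)pyrrolidin-1-yl on an aromatic carbon. The group that enters has no hydrogen-bond donor and lacks the isopropylcarbonyl amino arm of compound 3. Among the measured compounds shown here, the steps that bear on this are those in which compound 3 was reached from compound 1 and from compound 2, both large. In both of them the group that arrives is the one that carries that arm. Removing it is therefore expected to move the number back up, toward where compound 1 stands, because of a 12-fold lower number from compound 1 to compound 3 (1.08 log units; beyond the scatter). The step from compound 3 to compound 4 in this assay is expected to be a 20-fold higher number from compound 3 to compound 4 (1.30 log units; beyond the scatter). Compound 4 is estimated at 20 nM, within a range of 5 nM to 80 nM.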

Compound 4, half-maximal inhibitory concentration: 5 nM
Estimate against measurement, compound 4: 4.0-fold (0.60 log units) above; low and high end bracket the measured number.
By their numbers in this assay, from the lowest: compound 3; then compound 4; then compound 1; then compound 2.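

Losing the isopropylcarbonyl amino arm costs less in this assay than the earlier steps suggested, with a 5.0-fold higher number from compound 3 to compound 4 (0.70 log units; beyond the scatter), a modest step. Compound 4 has no hydrogen-bond donor, yet its small 2-methylpyrrolidin-1-yl still improves on both simpler amines, with a 2.4-fold lower number from compound 1 to compound 4 (0.38 log units; beyond the scatter) and an 18-fold lower number from compound 2 to compound 4 (1.25 log units; beyond the scatter), so at this position a low number does not depend on the arm. No measurement at hand explains these differences.

The compounds shown leave open whether the gain of compound 4 over the simpler amines comes from the five-membered ring or from its methyl, which a plain pyrrolidin-1-yl would separate. They also leave open how much of the remaining gap to compound 3 a simple amine on the pyrrolidine ring would recover, without the isopropylcarbonyl part.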